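The compounds below may be only part of what the source reports. "The series", "measured", "known", "first", "only" and "open" are said of these compounds alone.

Compound 1 `O=C1C(N2CCCC2)=CC(=O)c2c1nc1n2[C@H]2OC[C@@H](O)[C@H]2OC1` and compound 2 `O=C1C(N2CCC2)=CC(=O)c2c1nc1n2[C@H]2OC[C@@H](O)[C@H]2OC1` share one core and differ only in the group on a double-bonded ring carbon. In a functional assay on ECa-109 cells for inhibition, with ECa-109 cell line (Homo sapiens) as the target, read by sulforhodamine B assay (on this read-out higher numbers stand for weaker inhibition and lower numbers for stronger inhibition), compound 1 gives > 16000 nM, which is a limit of the assay and not a number. In this assay compound 2 likewise gives > 16000 nM, again a limit rather than a number. The step that the two limits leave unreadable from compound 1 to compound 2 therefore cannot be read, since both values sit at the same limit, as the limit of > 16000 nM in this assay, at which 2 of the 2 values shown sit, records. Compound 2 thus stands at the edge of what this assay can report, with no measured inhibition to place it more finely.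

Compound 3 `O=C1C(NCc2ccccc2)=CC(=O)c2c1nc1n2[C@H]2OC[C@@H](O)[C@H]2OC1` is the next member: benzylamino in place of azetidin-1-yl on a double-bonded ring carbon. No measured step bears directly on this change; the only step shown, from a pyrrolidin-1-yl to an azetidin-1-yl, was itself unreadable. With nothing to lean on, compound 3 is expected to stay near where compound 2 sits, and the step of a number no higher from compound 2 to compound 3 (the limit leaves the size open) is expected to be small or not resolvable. The estimate for compound 3 in this assay is 16000 nM, within a range from 3000 nM to 50000 nM.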

Compound 3, half-maximal inhibitory concentration: > 8000 nM
Compound 3: no number, only a limit; the forecaster's own chance of this, stated with the estimate: 60%; the middle value lies beyond the limit too.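

In this assay compound 3 gives > 8000 nM, which is a limit of the assay and not a number. For the compounds shown here, no step among compound 1, compound 2 and compound 3 can be read: all three values are limits. The compounds shown leave open whether pyrrolidin-1-yl, azetidin-1-yl and benzylamino differ at all in their inhibition of these cells.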